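A few compounds are considered here, and "the series" means these few. Any claim that something is new, unique, unknown or untested is made for them only; others in the source may bear on it.

In a functional assay on MCF7 cells (Homo sapiens) for antiproliferative activity, read by MTT assay, with a stated time of 72 h (a higher number here means a weaker inhibitor, a lower number a stronger inhibitor), compound 1 `COc1cccc(-c2ncnn2-c2cc(OC)c(OC)c(OC)c2)c1` gives > 10000 nM, which is a limit of the assay and not a number. Compound 2 `COc1cc(-n2ncnc2-c2ccc(OC(F)(F)F)cc2)cc(OC)c1OC` gives > 10000 nM, again only a limit. Among the compounds with values here, compound 3 `CCOc1ccc(-c2ncnn2-c2cc(OC)c(OC)c(OC)c2)cc1` gives 50 nM, the only true number here, and it stands apart from the limit of > 10000 nM in this assay, at which 2 of the 3 values shown sit. Compound 4 `COc1cc(-n2ncnc2-c2ccccc2)cc(OC)c1OC` carries hydrogen in place of ethoxy on an aromatic carbon, para to a large group (hydrogen in place of ethoxy on an aromatic carbon). Within the data shown here, the one measured step that bears on this spot is large: an at least 200-fold lower number from compound 2 to compound 3 (2.30 log units; beyond the scatter), with ethyl in place of trifluoromethyl on an oxygen. Losing ethoxy should therefore raise the number in this assay well beyond the scatter. The expected change is a 40-fold higher number from compound 3 to compound 4 (1.60 log units; beyond the scatter). For compound 4 the estimate is 2000 nM, with an expected range of 200 nM to 10000 nM.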

Compound 4, half-maximal inhibitory concentration: > 10000 nM
Compound 4 ended at the assay's limit; the forecaster's own chance of this, stated with the estimate: 35%; middle value at least 5.0-fold (0.69 log units) from the limit.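

Putting hydrogen in place of ethoxy on the aromatic carbon brings an at least 200-fold higher number from compound 3 to compound 4 (2.30 log units; beyond the scatter) in this assay. At this position the bare ring does not keep the low number, and trifluoromethoxy does not either, so among compounds 2, 3 and 4 only the ethoxy of compound 3 gives a true value: the limit of > 10000 nM in this assay, at which 3 of the 4 values shown sit. The steps from compound 1 and compound 2 to compound 4 cannot be read, as both ends of each are limits.

Still open, as far as these compounds go, is whether a longer chain such as propoxy, or an amine, at this position would keep the number low.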